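Series notes: a side-chain exchange on compound 1

This account rests on a few compounds, and the source may have more. Where it says the series, first, only, none or still open, it means among the compounds named here.

Measured so far in a functional assay on the whole organism (stomach) with Rattus norvegicus as the target; a lower number here means that less compound is needed, a higher number that more compound is needed for the effect:
- compound 1 `N#CNC(=N)NCCCn1nc(-c2ccccc2)ccc1=O` gives > 100 mg/kg, a limit of the assay and not a number.
- compound 2 `C/N=C(/NC#N)NCCCCn1nc(C)ccc1=O` gives > 100 mg/kg, likewise a limit.
- compound 3 `C/N=C(/NC#N)NCCCCCn1nc(-c2ccccc2)cc(C)c1=O` gives > 100 mg/kg, likewise a limit.

Compound 1 therefore stands nowhere on a scale of numbers: only a limit is known for it. Within the data shown here, the same holds for the other two compounds, so no order among compounds 1, 2 and 3 can be read from this assay, and no step between measured compounds is available. What the measured set shows is the limit of > 100 mg/kg in this assay, at which 3 of the 3 values shown sit, nothing more.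

Compound 4 `N/C(S)=N/CCCCn1nc(-c2ccccc2)ccc1=O` is the next to be measured. It differs from compound 1 in one place: a group of 5 heavy atoms (2 carbon, 2 nitrogen, 1 sulfur; no ring) in place of a group of 6 heavy atoms (2 carbon, 4 nitrogen; no ring), on a saturated chain carbon, three bonds along the chain from an aromatic nitrogen. The group that enters has one heavy atom fewer, one hydrogen-bond donor fewer and one hydrogen-bond acceptor fewer than the group that leaves, and brings a sulfur in place of two of the nitrogens.

Among the measured compounds shown here, with no measured step to lean on, no change beyond the scatter is expected from compound 1 to compound 4; the step of a number no higher from compound 1 to compound 4 (the limit leaves the size open) is an estimate only. For compound 4 the expected value is 100 mg/kg, with a range from 30 mg/kg to 300 mg/kg, and a limit rather than a number remains the likelier outcome.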

Compound 4, dose for half-maximal effect: 36.3 mg/kg
For compound 4 the middle estimate is 2.8-fold (0.44 log units) above the measured one, and the stated range covers the measured number.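

At the place on a saturated chain carbon, three bonds along the chain from an aromatic nitrogen, putting the group of 5 heavy atoms (2 carbon, 2 nitrogen, 1 sulfur; no ring) in place of the group of 6 heavy atoms (2 carbon, 4 nitrogen; no ring) gives an at least 2.7-fold lower number from compound 1 to compound 4 (0.44 log units; beyond the scatter) in this assay. This position is thus the first shown where a change produces a number in this read-out rather than another limit. Compound 4 stands alone in that respect, and the rest of the set remains as follows: the limit of > 100 mg/kg in this assay, at which 3 of the 4 values shown sit.

The step says nothing on how much of the change rests on the sulfur and how much on the loss of the other atoms of the leaving group, and a urea with oxygen in place of the sulfur, a plain amine or a carboxylic acid at this place would be needed to separate these. From the compounds shown here alone, whether the same group keeps its effect with a longer chain, or on the cores of compound 2 and compound 3, also stays open.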